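Hydroxy for Trifluoromethyl on Two Terpenoid Cores

A few compounds are considered here, and "the series" means these few. Any claim that something is new, unique, unknown or untested is made for them only; others in the source may bear on it.

Compound 1 `CC(C)=CCC/C(C)=C/CC/C(C)=C/CC[C@@H]1[C@@]2(C)CC/C(=N\OCc3cn(-c4cccc(C(F)(F)F)c4)nn3)C(C)(C)[C@@H]2CC[C@@]1(C)O` and compound 2 `CC(C)=CCC/C(C)=C/CC/C(C)=C/CC[C@@H]1[C@@]2(C)CC/C(=N\OCc3cn(-c4cccc(O)c4)nn3)C(C)(C)[C@@H]2CC[C@@]1(C)O` share one core; compound 3 `CC(C)=CCC/C(C)=C/CC/C(C)=C/CC[C@@H]1[C@@]2(C)C/C(=C\c3ccc(OCc4cn(-c5cccc(C(F)(F)F)c5)nn4)cc3)C(=O)C(C)(C)[C@@H]2CC[C@@]1(C)O` and compound 4 `CC(C)=CCC/C(C)=C/CC/C(C)=C/CC[C@@H]1[C@@]2(C)C/C(=C\c3ccc(OCc4cn(-c5cccc(O)c5)nn4)cc3)C(=O)C(C)(C)[C@@H]2CC[C@@]1(C)O` share another, and the difference between the two cores is not broken down here. In a functional assay on A549 cells (Homo sapiens) for cytotoxicity, read by MTT assay, with a stated time of 48 h (a higher number here means a weaker inhibitor, a lower number a stronger inhibitor), compound 1 gives 12900 nM and compound 2 gives 12800 nM. The change between them, (hydroxy in place of trifluoromethyl on an aromatic carbon), made a step of a 1.0-fold lower number from compound 1 to compound 2 (0.00 log units; within the scatter). In this assay compound 3 gives 23200 nM, the highest of the three numbers, though both gaps to it are within the scatter. The same change, (hydroxy in place of trifluoromethyl on an aromatic carbon), now sits on the other core, and compound 4 is not yet measured. Because the earlier step measured a 1.0-fold lower number from compound 1 to compound 2 (0.00 log units; within the scatter), for compound 4 a step of similar size is expected, a 1.1-fold lower number from compound 3 to compound 4 (0.02 log units; within the scatter). Compound 4 is therefore estimated at 22000 nM, with a likely range from 11000 nM to 45000 nM.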

Compound 4, half-maximal inhibitory concentration: 110000 nM
The estimate for compound 4 lay 5.0-fold (0.70 log units) below the measured number; measured number outside the range, above it.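

In this assay, hydroxy in place of trifluoromethyl made a 4.7-fold higher number from compound 3 to compound 4 (0.68 log units; beyond the scatter), so on this core the change weakened the compound, whereas on the core of compound 1 it left the number unchanged within the scatter. The step therefore did not carry over from one core to the other: the same change on two cores in this assay, a 1.0-fold lower number (0.00 log units; within the scatter) from compound 1 to compound 2 and a 4.7-fold higher number (0.68 log units; beyond the scatter) from compound 3 to compound 4, 4.8-fold (0.68 log units) apart, beyond the scatter of two such steps. With a single pair on each core, this shows that the result of the change can depend on the core, but not why it does or how it would play out on any other core.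

On these data alone, it remains open how other groups at this place, such as an amine or a carboxylic acid, would behave on the two cores. Whether they would also give different steps on each core cannot be told from these four compounds.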